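This account rests on a few compounds, and the source may have more. Where it says the series, first, only, none or still open, it means among the compounds named here.

Compounds measured so far: compound 1 `Cc1nn(-c2ncnc3nc[nH]c23)c2c1C(OCC(=O)c1ccc(F)cc1)CC(=O)N2` gives 973 nM; compound 2 `Cc1nn(-c2ncnc3nc[nH]c23)c2c1C(OCc1ccc(Cl)cc1Cl)CC(=O)N2` gives 243 nM; compound 3 `Cc1nn(-c2ncnc3nc[nH]c23)c2c1C(OCCn1nccc1C)CC(=O)N2` gives 1620 nM.

In a functional assay on HEK293 cells for agonist activity at G-protein coupled receptor 39 (Homo sapiens), read by scintillation proximity assay and inositol phosphate accumulation, with a stated time of 75 min (a higher number here means that more compound is needed for the effect, a lower number that less compound is needed), compound 3 has the highest number of the three. One of its steps lies beyond the scatter, a 6.7-fold higher number from compound 2 to compound 3 (0.82 log units; beyond the scatter), while the other, a 1.7-fold higher number from compound 1 to compound 3 (0.22 log units; within the scatter), is within the scatter, so compound 1 and compound 3 cannot be ordered with confidence.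

Compound 4 `Cc1nn(-c2ncnc3nc[nH]c23)c2c1C(OC(=O)c1ccc(F)cc1)CC(=O)N2` changes the side chain of compound 3: a group of 9 heavy atoms (7 carbon, 1 oxygen, 1 fluorine; one six-membered aromatic ring of carbon only) in place of a group of 8 heavy atoms (6 carbon, 2 nitrogen; one five-membered aromatic ring with 2 hetero atoms), on an oxygen on a saturated carbon. The group that enters is the same one found in compound 1, but it now sits directly on the oxygen rather than one carbon further out. The step of a 1.7-fold higher number from compound 1 to compound 3 (0.22 log units; within the scatter) therefore bears most closely on this change; it was within the scatter, so reversing it gives no strong expectation of movement. The step of a 6.7-fold higher number from compound 2 to compound 3 (0.82 log units; beyond the scatter) shows that a six-membered carbon-only aromatic ring on this chain can lower the number, but compound 2 carries different substituents. A small step downward is expected, a 2.0-fold lower number from compound 3 to compound 4 (0.31 log units; beyond the scatter), with wide uncertainty. Compound 4 is estimated at 800 nM, likely between 200 nM and 3500 nM.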

Compound 4, half-maximal effective concentration: 245 nM
Compound 4: middle estimate off by 3.3-fold (0.51 log units), on the high side, and the stated range covers the measured number.
By their numbers in this assay, from the lowest: compounds 2 and 4 (each within the scatter of the next); then compounds 1 and 3 (each within the scatter of the next).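

Shortening the link matters at this position: taking out the one carbon between the oxygen and the (4-fluorophenyl)carbonyl group gives a change beyond the scatter (a 4.0-fold lower number from compound 1 to compound 4 (0.60 log units; beyond the scatter)). With the group directly on the oxygen, replacing the side chain with its five-membered aromatic ring also gives a change beyond the scatter (a 6.6-fold lower number from compound 3 to compound 4 (0.82 log units; beyond the scatter)), so the earlier near-tie between these two side chains does not hold once the link is shortened. Two different groups on this oxygen, (4-fluorophenyl)carbonyl and 2,4-dichlorobenzyl, cannot be told apart here (a 1.0-fold higher number from compound 2 to compound 4 (0.00 log units; within the scatter)).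

Nothing available explains these differences. Going by these compounds, the role of the carbonyl remains open, as does the effect of a plain 4-fluorobenzyl group, an amine or a carboxylic acid on this oxygen.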